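The source may hold more compounds than are shown below. What is called first, only, known or untested is meant among the compounds shown, and "the series" means these compounds.

Of the compounds shown here, three built on one shared core have been measured in an assay on isolated protein for inhibition of Amine oxidase [flavin-containing] B (Homo sapiens), read by fluorescence, with a stated time of 30 min; on this read-out lower numbers stand for stronger inhibition and higher numbers for weaker inhibition. Compound 1 `COC(=O)C(C)c1ccc(-c2ccc(C(=O)/C=C/c3ccc(CN4CCN(C)CC4)c(O)c3)cc2)c(F)c1` gives 430 nM there, compound 2 `COC(=O)C(C)c1ccc(-c2ccc(C(=O)/C=C/c3ccc(CN(C)C)c(O)c3)cc2)c(F)c1` gives 430 nM, and compound 3 `CCN1CCN(Cc2ccc(/C=C/C(=O)c3ccc(-c4ccc(C(C)C(=O)OC)cc4F)cc3)cc2O)CC1` gives 430 nM, so compound 3 stands level with both of the others. Compound 4 `CCN(CC)Cc1ccc(/C=C/C(=O)c2ccc(-c3ccc(C(C)C(=O)OC)cc3F)cc2)cc1O` differs from compound 3 by diethylamino in place of 4-ethylpiperazin-1-yl on a saturated chain carbon bound to an aromatic carbon. Two earlier changes of the amine on that same carbon bear on this: no change at the digits printed from compound 1 to compound 2 (within the scatter) and no change at the digits printed from compound 2 to compound 3 (within the scatter), both flat, as was the ring methylation no change at the digits printed from compound 1 to compound 3 (within the scatter). A further amine swap at that carbon is therefore expected to give no step beyond the scatter in this assay; the expected step is no change at the digits printed from compound 3 to compound 4 (within the scatter). Compound 4 is thus estimated at 430 nM, expected between 200 nM and 900 nM.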

Compound 4, half-maximal inhibitory concentration: 430 nM
For compound 4 middle estimate and measured number coincide at the digits printed; measured number inside the range.
By their numbers in this assay, from the lowest: compounds 1, 2, 3 and 4 (each within the scatter of the next).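

In this assay, diethylamino on a saturated chain carbon bound to an aromatic carbon gives no change at the digits printed from compound 3 to compound 4 (within the scatter) and no change at the digits printed from compound 1 to compound 4 (within the scatter) when it replaces the two piperazine groups. Against dimethylamino it gives no change at the digits printed from compound 2 to compound 4 (within the scatter), so the flat result now spans two open-chain amines as well as both ring amines at this position. Nothing measured here accounts for this flatness. The compounds shown leave open whether a primary amine or morpholin-4-yl on that carbon would stay level. They also leave open whether a carboxylic acid in place of the methyl ester would shift the read-out.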